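Halogen swap on the anilide of a nitrobenzofurazan ester

A few compounds are considered here, and "the series" means these few. Any claim that something is new, unique, unknown or untested is made for them only; others in the source may bear on it.

Measured compounds:
compound 1 `O=C(CCC(=O)OCCCCCCSc1ccc([N+](=O)[O-])c2nonc12)Nc1ccccc1` — 10200 nM
compound 2 `O=C(CCC(=O)OCCCCCCSc1ccc([N+](=O)[O-])c2nonc12)Nc1cccc(Cl)c1` — 28800 nM

Both compounds were tested in an assay on isolated protein for inhibition of glutathione S-transferase P (Homo sapiens), with a stated time of 10 min; a lower number here means a stronger inhibitor, a higher number a weaker inhibitor. Compound 1, which carries a plain phenyl on the amide nitrogen, gives 10200 nM. Compound 2, with a chloro in place of hydrogen on an aromatic carbon, gives 28800 nM, the higher of the two numbers; the step of a 2.8-fold higher number from compound 1 to compound 2 (0.45 log units; beyond the scatter) lies beyond the scatter, so compound 2 is the weaker inhibitor of the pair.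

Compound 3 `O=C(CCC(=O)OCCCCCCSc1ccc([N+](=O)[O-])c2nonc12)Nc1ccc(F)cc1` has not yet been measured. It differs from compound 2 by 4-fluorophenyl in place of 3-chlorophenyl on an amide-type nitrogen. Among the compounds with values here, the only step on record is the one from compound 1 to compound 2, and it concerns a chloro entering where hydrogen stood, not a fluoro at a different position, so it bears on the new change only loosely. Since adding chloro raised the number, and compound 3 carries a different halogen instead, a number between compound 1 and compound 2 seems most plausible, with the step of a 1.8-fold lower number from compound 2 to compound 3 (0.26 log units; within the scatter) expected to be small and near the scatter. Compound 3 is therefore estimated at 16000 nM, within 6000 nM to 40000 nM.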

Compound 3, half-maximal inhibitory concentration: 8570 nM
Compound 3: the middle estimate sits 1.9-fold (0.27 log units) above what was measured; low and high end bracket the measured number.
By their numbers in this assay, from the lowest: compounds 3 and 1 (each within the scatter of the next); then compound 2.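

In this assay, replacing 3-chlorophenyl with 4-fluorophenyl on the amide-type nitrogen gives a 3.4-fold lower number from compound 2 to compound 3 (0.53 log units; beyond the scatter) and so yields the stronger inhibitor of that pair. Setting the 4-fluorophenyl against the plain phenyl gives a 1.2-fold lower number from compound 1 to compound 3 (0.08 log units; within the scatter) and leaves compound 3 indistinguishable from compound 1, so among these three compounds, a halogen on the phenyl does not always bring a weaker inhibitor: compound 2 shows that loss, while compound 3 goes against any such rule. No measurement on hand explains why the two halogen-bearing phenyl groups part in this way.

The step from the 3-chlorophenyl to the 4-fluorophenyl changes both the halogen and its place on the ring at once, so these compounds cannot show which of the two changes matters, or whether both do. On these data alone, how a bromo, a methoxy, an amine or a carboxylic acid on this phenyl would fare remains open, as does whether a larger change at this position could move the number well beyond the small range seen so far.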